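The compounds below may be only part of what the source reports. "The series", "measured", "known", "first", "only" and "open" are said of these compounds alone.

Measured so far in a functional assay on HCT-15 cells (Homo sapiens) for cytotoxicity, read by sulforhodamine B assay, with a stated time of 48 h, tested at 0.01 uM; on this read-out lower numbers stand for a stronger effect and higher numbers for a weaker effect at the one concentration tested:
- compound 1, `COc1cc(C)cc(-c2c(-c3ccnc(-c4ccc(C(C)=O)cc4)c3)cnn2CC#N)c1`: 95%
- compound 2, `COc1cc(C)cc(-c2nn(CC#N)cc2-c2ccc(-c3cccc(C(C)=O)c3)nc2)c1`: 100%
- compound 3, `Cc1cc(O)cc(-c2nn(CC#N)cc2-c2ccnc(-c3ccc(N(C)C)cc3)c2)c1`: 92%

All three numbers lie close together. Compound 1 sits within the scatter of both other compounds: its nearest neighbour is compound 3, its furthest is compound 2, and neither gap is more than the usual spread of repeated measurements. At the single concentration tested, none of the three shows more than a marginal effect, and no comparison among them can be read as a real difference.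

The next compound, compound 4, `COc1cc(C)cc(-c2c(-c3ccnc(-c4ccc(N(C)C)cc4)c3)cnn2CC#N)c1`, is to be measured in this assay. It differs from compound 1 in one place only: dimethylamino in place of acetyl on an aromatic carbon. Within the data shown here, no pair of measured compounds differing in one place is available, so there is no step to lean on. Compound 3 does carry a dimethylamino group on its own aryl ring and gives 92%, which shows that this group is not accompanied by a markedly stronger effect in the series as it stands.

The step of a number 1 percentage points lower from compound 1 to compound 4 (within the scatter) is therefore expected to be none beyond the scatter. Compound 4 is expected to give 94%, within a range from 82% to 104%.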

Compound 4, a percentage reported as activity, at one concentration (the size of the read-out at that concentration, not a potency): 12%
Estimate against measurement, compound 4: 82 percentage points above; the measured number lies below the stated range.
By their numbers in this assay, from the lowest: compound 4; then compounds 3, 1 and 2 (each within the scatter of the next).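

In this assay, among these compounds, dimethylamino in place of acetyl on this aromatic carbon gives a number 83 percentage points lower from compound 1 to compound 4 (beyond the scatter), the first single change seen to move the read-out beyond the scatter. The position, para to a large group, is therefore not indifferent to what it carries, even though the two groups share the same count of heavy atoms and of hydrogen-bond acceptors, and neither carries a net charge. Nothing measured here accounts for the step, so its cause remains unassigned.

As far as these compounds go, whether the step needs dimethylamino itself stays open, since an unsubstituted amine or a morpholine ring at this place would separate the role of the nitrogen from that of its substituents. Among the compounds shown here, the read-out also comes from one concentration, so the step gives no potency for either compound.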